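The source may report more compounds than this note shows. Statements on the series, on what has been measured and on what is new or still open speak of the compounds shown alone.

Compound 1, `C=CC1=C(C(=O)NCc2ccc(Cl)cc2)C(c2ccc(OC)c(OC)c2)OC1`. In a functional assay on A549 cells (Homo sapiens) for cytotoxicity, read by MTT assay, with a stated time of 24 h (a lower number here means a stronger inhibitor, a higher number a weaker inhibitor), compound 1 gives > 100000 nM, which is a limit of the assay and not a number.
Compound 2, `C=CC1=C(C(=O)NCc2ccc(Cl)cc2)C(c2ccc(OC)cc2)OC1`. In this assay compound 2 gives > 100000 nM, again a limit.
Compound 3, `C=CC1=C(C(=O)Nc2ccccc2OC)C(c2ccc(F)cc2)OC1`. In this assay compound 3 gives > 100000 nM, again a limit.

For the measured compounds named here, compound 2 therefore stands nowhere in particular on the numbers: the limit of > 100000 nM in this assay, at which 3 of the 3 values shown sit, so no compound here has a readable value. Going by the values given here, the one measured step, a step that the two limits leave unreadable from compound 1 to compound 2, cannot be sized for the same reason.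

Compound 4, `C=CC1=C(C(=O)NC2CCCCC2)C(c2ccc(OC)cc2)OC1`, is not yet measured in this assay. It differs from compound 2 by cyclohexyl in place of 4-chlorobenzyl on an amide-type nitrogen. Among the compounds with values here, no measured step here bears on this change; none of the three measured compounds carries a cyclohexyl on the amide-type nitrogen, and no comparison among them involves that position.

Within the data shown here, with every value so far sitting at the limit, compound 4 is expected to sit there too, so the estimated step that the limit leaves unreadable from compound 2 to compound 4 is none beyond the scatter. Compound 4 is estimated at 150000 nM, within 40000 nM to 600000 nM.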

Compound 4, half-maximal inhibitory concentration: > 100000 nM
Compound 4 was reported as a limit (the forecaster's own chance of this, stated with the estimate: 80%); the middle value lies beyond the limit too.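

Compound 2 and compound 4 both sit at a limit of the assay and not at a number, so the swap of 4-chlorobenzyl for cyclohexyl gives no readable step: the limit of > 100000 nM in this assay, at which 4 of the 4 values shown sit.

The compounds shown leave open whether any change to the shared core can produce a readable value in this assay.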